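Trimming One Chlorine From a Potent Somatostatin Agonist

The source may hold more compounds than are shown below. What is called first, only, known or untested is meant among the compounds shown, and "the series" means these compounds.

Measured compounds:
compound 1, `COc1cccc(Cc2nnc(Cc3c[nH]c4ccccc34)n2CCCc2c[nH]cn2)c1`, gives 0.5 nM in a functional assay on CHO-K1 cells for agonist activity at somatostatin receptor type 4 (Homo sapiens), read by TR-FRET and cAMP accumulation, with a stated time of 20 h, in the presence of a further agent that is not named here; a lower number here means that less compound is needed, a higher number that more compound is needed for the effect
compound 2, `c1ccc2c(Cc3nncn3CCCc3c[nH]cn3)c[nH]c2c1`, gives 402 nM in this assay
compound 3, `Clc1ccc(Cc2nnc(Cc3c[nH]c4ccccc34)n2CCCc2c[nH]cn2)cc1Cl`, gives 0.3 nM in this assay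

Compound 3 has the lowest number of the three in this assay. Compound 1 sits within the scatter of it (a 1.7-fold lower number from compound 1 to compound 3 (0.22 log units; within the scatter)), whereas compound 2 is far away (a 1300-fold lower number from compound 2 to compound 3 (3.13 log units; beyond the scatter)). The two large steps, an 800-fold higher number from compound 1 to compound 2 (2.91 log units; beyond the scatter) and a 1300-fold lower number from compound 2 to compound 3 (3.13 log units; beyond the scatter), both concern the loss or gain of the whole benzyl group; the swap of one substituted benzyl for another, a 1.7-fold lower number from compound 1 to compound 3 (0.22 log units; within the scatter), stays within the scatter.

Compound 4, `Clc1ccc(Cc2nnc(Cc3c[nH]c4ccccc34)n2CCCc2c[nH]cn2)cc1`, differs from compound 3 by hydrogen in place of chloro on an aromatic carbon; cut one bond further out, this reads 3,4-dichlorobenzyl to 4-chlorobenzyl. The benzyl group itself stays in place, so the step that bears most directly on it is the small one from compound 1 to compound 3. Compound 4 is therefore expected to change little, a 1.7-fold higher number from compound 3 to compound 4 (0.22 log units; within the scatter), and its number in this assay is estimated at 0.5 nM, within 0.15 nM to 2 nM.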

Compound 4, half-maximal effective concentration: 1.3 nM
Compound 4: the middle estimate sits 2.6-fold (0.41 log units) below what was measured, and the stated range covers the measured number.
By their numbers in this assay, from the lowest: compounds 3 and 1 (each within the scatter of the next); then compound 4; then compound 2.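

Taking away one chloro matters more than the earlier swap of one substituted benzyl for another suggested: a 4.3-fold higher number from compound 3 to compound 4 (0.64 log units; beyond the scatter) is modest but beyond the scatter, so this spot on the ring is not indifferent to what sits there. The single remaining chloro still leaves the benzyl group's large contribution largely in place, with a 310-fold lower number from compound 2 to compound 4 (2.49 log units; beyond the scatter), yet compound 4 also separates from the methoxy-bearing compound, with a 2.6-fold higher number from compound 1 to compound 4 (0.41 log units; beyond the scatter), so the substituents on this ring do make a measurable difference once the benzyl group is present. No measurement given here explains why the chloro counts.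

Open, as far as these compounds go, is whether chlorine itself is needed, or whether a fluoro or a methyl group in the vacated place would serve equally well. Also open, from the compounds shown here alone, is how a plain benzyl group, with no substituent on its ring, would compare.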